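The source may hold more compounds than are shown below. What is called first, only, known or untested is meant among the compounds shown, and "the series" means these compounds.

Measured so far:
- Compound 1, `O=C1O[C@]2(CC[C@H](CNc3cnn(-c4ccccc4F)c3)CC2)CN1c1cccnc1F`: 0.1 nM
- Compound 2, `O=C1O[C@]2(CC[C@H](CNc3ccc(OC4CCC4)cn3)CC2)CN1c1ccccn1`: 0.159 nM

Both compounds were tested in a functional assay for antagonist activity at Neuropeptide Y receptor type 5 (Homo sapiens); a lower number here means a stronger inhibitor, a higher number a weaker inhibitor. Compound 1 gives 0.1 nM, and compound 2 gives 0.159 nM; the two numbers lie within the scatter of each other, so neither can be set apart from the other on these results. For the measured compounds named here, the two structures differ in more than one place, and no single step between them can be read off.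

Compound 3, `O=C1O[C@]2(CC[C@H](CNc3ccc(C(F)(F)F)cn3)CC2)CN1c1ccccn1`, has not yet been measured in this assay. It differs from compound 2 in one place: trifluoromethyl in place of cyclobutyloxy on an aromatic carbon. Going by the values given here, with no step of this kind among the measured compounds, the size of the change can only be guessed. The expectation is a small step in this assay, toward a slightly higher number, of about a 1.9-fold higher number from compound 2 to compound 3 (0.28 log units; within the scatter). On that basis compound 3 is estimated at 0.3 nM, with a likely range from 0.08 nM to 1.2 nM.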

Compound 3, inhibition constant: 1 nM
For compound 3 the middle estimate is 3.3-fold (0.52 log units) below the measured one; the measured number falls inside the stated range.
By their numbers in this assay, from the lowest: compounds 1 and 2 (each within the scatter of the next); then compound 3.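

For the compounds shown here, replacing cyclobutyloxy with trifluoromethyl at this position, two atoms from the ring nitrogen, is the first single change that can be read in this assay, and it gives a 6.3-fold higher number from compound 2 to compound 3 (0.80 log units; beyond the scatter). The result shows that this position is sensitive to which group it carries, as this one change produces a step beyond the usual scatter. The group that leaves has a ring and a hydrogen-bond acceptor while the group that enters has neither, but nothing available explains the loss of potency.

A methoxy group would keep the oxygen without the ring, and a cyclobutyl group would keep the ring without the oxygen, so this pair alone cannot show which feature matters. On these data alone, whether the same change would have a similar effect on other parts of the series also remains open.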